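The compounds below may be only part of what the source reports. "The series", "measured", "known", "first", "only" and "open" are said of these compounds alone.

In a functional assay on HT-29 cells (Homo sapiens) for inhibition, read by MTT assay, with a stated time of 48 h (a lower number here means a stronger inhibitor, a higher number a weaker inhibitor), compound 1 `COc1ccc(-n2c(S)nnc2-c2cc(OC)c(OC)c(OC)c2)cc1` reads > 60000 nM, which is a limit of the assay. Compound 2 `COc1ccc(-n2c(SCC(=O)Nc3ccc(Cl)cc3)nnc2-c2cc(OC)c(OC)c(OC)c2)cc1` gives 58000 nM. Compound 3 `COc1cc(-c2nnc(S)n2-c2ccc(N(C)C)cc2)cc(OC)c1OC` reads > 60000 nM, also a limit, and the step from the first compound is unreadable: a step that the two limits leave unreadable from compound 1 to compound 3. Compound 3 therefore stands at the limit of > 60000 nM in this assay, at which 2 of the 3 values shown sit. Compound 4 `COc1cc(-c2nnc(SCc3ccc(C)cc3)n2-c2ccc(N(C)C)cc2)cc(OC)c1OC` differs from it by 4-methylbenzyl in place of hydrogen on a sulfur, with 4-methylbenzyl in place of hydrogen on a sulfur. Within the data shown here, the one measured step on that sulfur, with a different group entering, is an at least 1.0-fold lower number from compound 1 to compound 2 (0.01 log units; that floor lies within the scatter), so it shows only a floor within the scatter. A modest move to a lower number is therefore expected, with its size uncertain: an at least 2.0-fold lower number from compound 3 to compound 4 (0.30 log units; that floor lies within the scatter). Compound 4 is estimated at 30000 nM, with an expected range of 6000 nM to 60000 nM.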

Compound 4, half-maximal inhibitory concentration: 27500 nM
For compound 4 the middle estimate is 1.1-fold (0.04 log units) above the measured one; measured number inside the range.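

In this assay, among these compounds, the sulfur takes 4-methylbenzyl in place of hydrogen with an at least 2.1-fold lower number from compound 3 to compound 4 (0.33 log units; beyond the scatter) and so gives the first step at this position that clears the scatter. The earlier step on that sulfur, with ((4-chlorophenyl)carbamoyl)methyl entering, showed only a floor within the scatter. Compound 3 reads as a limit, so this step too has only a floor: the limit of > 60000 nM in this assay, at which 2 of the 4 values shown sit.

Open, going by these compounds, is how a plain benzyl, a simple methyl or a chain ending in a carboxylic acid or an amine would read on that sulfur. Also open, on these data alone, is whether 4-methylbenzyl moves the number as far on the core of compound 1.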